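A few compounds are considered here, and "the series" means these few. Any claim that something is new, unique, unknown or untested is made for them only; others in the source may bear on it.

Working notes on the series. Compound 2 `O=c1c(C(=S)Nc2ccccc2)coc2cc(Cl)ccc12` gives 90800 nM in a functional assay on PC-3 cells (Homo sapiens) for inhibition, read by sulforhodamine B assay, with a stated time of 48 h (a higher number here means a weaker inhibitor, a lower number a stronger inhibitor), and the nearest value is that of compound 3 `O=c1c(C2N=C(c3ccccc3)SS2)coc2ccc(Cl)cc12` at 52700 nM, a gap that lies within the scatter. Compound 1 `Cc1ccc2occ(C3N=C(c4ccccc4)SS3)c(=O)c2c1` reaches only the limit of > 100000 nM in this assay. Compound 4 `O=c1c(C(=S)Nc2ccccc2)coc2cc(Cl)c(Cl)cc12` is the next member to be measured; it differs from compound 2 by chloro in place of hydrogen on an aromatic carbon.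

Among the compounds with values here, the only measured step, an at least 1.8-fold lower number from compound 1 to compound 3 (0.27 log units; that floor lies within the scatter), concerns a chloro in place of methyl on a different core, and one end of it is a limit (the limit of > 100000 nM in this assay, at which 1 of the 3 values shown sits), so it says little about adding a second chloro to the core of compound 2. Within the data shown here, no measured step repeats the change from compound 2 to compound 4, and no value here rises or falls beyond the scatter.

On this basis compound 4 is expected to stay close to compound 2, with an estimated step of a 1.2-fold lower number from compound 2 to compound 4 (0.08 log units; within the scatter) that does not leave the scatter. Compound 4 is estimated at 75000 nM in this assay, within 25000 nM to 200000 nM.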

Compound 4, half-maximal inhibitory concentration: 95400 nM
For compound 4 the middle estimate is 1.3-fold (0.10 log units) below the measured one, within the range that was stated.
By their numbers in this assay, from the lowest: compounds 3, 2 and 4 (each within the scatter of the next). At a limit, above all of these: compound 1.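

Adding a chloro on the aromatic carbon ortho to the chloro group of compound 2 gives a 1.1-fold higher number from compound 2 to compound 4 (0.02 log units; within the scatter) in this assay, so on this core the position takes a second chloro with no readable change in the number. Within the data shown here, this is the only step on the core shared by compound 2 and compound 4, and it gives a direct reading of this change in place of an inference from a different core. Compound 1 remains a limit and not a number, and it adds no measured size to this comparison: the limit of > 100000 nM in this assay, at which 1 of the 4 values shown sits.

From the compounds shown here alone, whether another group at this position, such as an amine, a methoxy group or a carboxylic acid, would move the number beyond the scatter stays open. So does the effect of the same chloro on the core of compound 3.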